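The source may hold more compounds than are shown below. What is called first, only, known or untested is meant among the compounds shown, and "the series" means these compounds.

Measured compounds:
compound 1 `CCCCC(O)c1cccc(NC(=O)NC(=O)CCl)c1` gives 4600 nM
compound 2 `CCCCC(OC)c1cccc(NC(=O)NC(=O)CCl)c1` gives 4200 nM

Both numbers come from a functional assay on M21 cells (Homo sapiens) for antiproliferative activity, with a stated time of 48 h; a lower number here means a stronger inhibitor, a higher number a weaker inhibitor. Compound 2 holds the lowest of the two numbers, but compound 1 sits within the scatter of it, so the two cannot be told apart. Among the compounds with values here, the single measured step, a 1.1-fold lower number from compound 1 to compound 2 (0.04 log units; within the scatter), swaps a hydroxyl for a methoxy on the side chain and says nothing about the part that changes next.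

Compound 3 `CCCCC(OC)c1cccc(NC(=O)CCl)c1` differs from compound 2 in one place: chloromethyl in place of ((chloromethyl)carbonyl)amino on a carbonyl carbon. Seen one bond further out, a ((chloromethyl)carbonyl)carbamoyl becomes a (chloromethyl)carbonyl, so the chain between the ring nitrogen and the chloromethyl is shortened, and one hydrogen-bond donor and one hydrogen-bond acceptor go with it. Within the data shown here, no measured step touches this part, so the expectation rests on compound 2 alone and carries wide uncertainty. The step is expected to be a 1.7-fold higher number from compound 2 to compound 3 (0.22 log units; within the scatter), in the direction of a somewhat weaker inhibitor, though the range allows no change beyond the scatter. Compound 3 is therefore estimated at 7000 nM, with a range from 1800 nM to 28000 nM.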

Compound 3, half-maximal inhibitory concentration: 6900 nM
Beside the measured number, compound 3's estimate is 1.0-fold (0.01 log units) above it; low and high end bracket the measured number.
By their numbers in this assay, from the lowest: compounds 2, 1 and 3 (each within the scatter of the next).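

Within the data shown here, this is the first look at the part of the molecule that carries the chloromethyl. In this assay, chloromethyl in place of ((chloromethyl)carbonyl)amino on a carbonyl carbon gives a 1.6-fold higher number from compound 2 to compound 3 (0.22 log units; within the scatter). The change removes one hydrogen-bond donor and one hydrogen-bond acceptor and shortens the chain, yet the two compounds cannot be told apart in this cell read-out, so the longer group is not needed to keep a number of this size, at least with the methoxy side chain of compound 3. Nothing available here bears on how either group acts in these cells.

Among these compounds, all the steps so far lie within the scatter, so it remains unclear which part of these molecules the number depends on. All three compounds keep the chloromethyl, so the effect of replacing it with a plain methyl or an amine is an open question, as is whether a longer chain in place of the side chain's butyl portion would move the number beyond the scatter.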